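The source may report more compounds than this note shows. Statements on the series, on what has been measured and on what is new or still open speak of the compounds shown alone.

In a functional assay on a cell-free system (Platelet, plasma, Oryctolagus cuniculus) for inhibition, with a stated time of 5 min (a higher number here means a weaker inhibitor, a lower number a stronger inhibitor), compound 1 (`CCOC(=O)/C=C/c1ccccc1OCc1nc(C)c(C)nc1C`) gives 502000 nM. Compound 2 (`CCOC(=O)/C=C/c1cccc(OC)c1OCc1nc(C)c(C)nc1C`) gives > 2000000 nM, which is a limit of the assay and not a number. Compound 3 (`CCOC(=O)/C=C/c1cc(Br)cc(Br)c1OCc1nc(C)c(C)nc1C`) gives > 2000000 nM, also a limit. Compound 2 therefore stands at the limit of > 2000000 nM in this assay, at which 2 of the 3 values shown sit.

Among the measured compounds shown here, the one measured step that touches compound 2 is an at least 3.9-fold higher number from compound 1 to compound 2 (0.60 log units; beyond the scatter), with methoxy in place of hydrogen on an aromatic carbon. Compound 4 (`COc1cccc(/C=C/C(=O)O)c1OCc1nc(C)c(C)nc1C`) keeps that methoxy group and changes elsewhere: hydrogen in place of ethyl on an oxygen next to a carbonyl group. This is hydrogen in place of ethyl on an oxygen next to a carbonyl group, so ethoxycarbonyl becomes carboxy.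

For the measured compounds named here, no measured step covers this change, and the methoxy step offers only a loose guide to its size. With only a limit as the starting point, a modest move to a lower number in this assay is expected, with wide uncertainty. The expected size of the change is an at least 2.5-fold lower number from compound 2 to compound 4 (0.39 log units; beyond the scatter). The estimated value for compound 4 is 800000 nM, within an expected range of 150000 nM to 2500000 nM.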

Compound 4, half-maximal inhibitory concentration: 522000 nM
Beside the measured number, compound 4's estimate is 1.5-fold (0.19 log units) above it; low and high end bracket the measured number.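

In this assay, the change from ethoxycarbonyl to carboxy gives an at least 3.8-fold lower number from compound 2 to compound 4 (0.58 log units; beyond the scatter). Compound 4 still carries the methoxy group and gives 522000 nM. That group alone therefore does not keep a compound at the limit of the assay. On these data alone, the true size of the step stays unknown, because its starting point is a limit and not a number: the limit of > 2000000 nM in this assay, at which 2 of the 4 values shown sit.

As far as these compounds go, it remains open whether the same change from ethoxycarbonyl to carboxy would lower the number for compound 1, which has no methoxy group, or for compound 3, which carries two bromo groups. Also open, from the compounds shown here alone, is what an amide or a carboxylic acid on a longer chain would give in place of the carboxy group of compound 4.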